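The source may hold more compounds than are shown below. What is called first, only, known or untested is meant among the compounds shown, and "the series" means these compounds.

Three compounds of this series have been run in a functional assay on SW480 cells (Homo sapiens) for cytotoxicity, read by MTT assay, with a stated time of 48 h; a lower number here means a stronger inhibitor, a higher number a weaker inhibitor. Compound 1 `CCOC(=O)[C@@H]1C[C@@]23CN(C)C[C@@H](CCC4=C2[C@@H]1CC4=O)C31CC[C@](CC)(OC)OC1` returns only a limit of the assay, > 40000 nM. Compound 2 `CC[C@]1(OC)CCC2(CO1)[C@@H]1CCC3=C4[C@H](CC3=O)[C@H](C(=O)OC)C[C@@]42CN(C)C1` likewise returns a limit, > 40000 nM. Compound 3 `CCC1=CCC2(CO1)[C@@H]1CCC3=C4[C@H](CC3=O)[C@H](C(=O)OC)C[C@@]42CN(C)C1` also stops at a limit, > 40000 nM. The difference between the core of compound 2 and the core of compound 3 is not broken down here. From compound 2 to compound 1 the change is methyl in place of hydrogen on a saturated chain carbon bound to an oxygen next to a carbonyl group; the step that the two limits leave unreadable from compound 2 to compound 1 cannot be read, because of the limit of > 40000 nM in this assay, at which 3 of the 3 values shown sit. Compound 4 `COC(=O)[C@@H]1C[C@@]23CN(C)C[C@@H](CCC4=C2[C@@H]1CC4=O)C31CC=C(C(C)C)OC1` is not yet measured; it differs from compound 3 by methyl in place of hydrogen on a saturated chain carbon bound to a double-bonded ring carbon and a saturated chain carbon, the same kind of change at another place, a saturated chain carbon bound to a double-bonded ring carbon and a saturated chain carbon rather than one bound to an oxygen next to a carbonyl group. For the measured compounds named here, a step of a number no higher from compound 3 to compound 4 (the limit leaves the size open) is expected in this assay, because the limit of > 40000 nM in this assay, at which 3 of the 3 values shown sit, holds for every value so far. Compound 4 is estimated at 40000 nM, between 20000 nM and 80000 nM.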

Compound 4, half-maximal inhibitory concentration: > 40000 nM
Compound 4: only a limit was reported; the forecaster's own chance of this, stated with the estimate: 85%; the middle value lies on the limit itself.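

No step can be read between compound 3 and compound 4, as both stop at a limit: the limit of > 40000 nM in this assay, at which 4 of the 4 values shown sit. The compounds shown leave open what change to the series would give a measurable value.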